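Trifluoromethoxyphenyl in Place of Fluoropyridinyl on a Shared Core

A few compounds are considered here, and "the series" means these few. Any claim that something is new, unique, unknown or untested is made for them only; others in the source may bear on it.

The study reads cytotoxicity in an ADME assay on HeLa cells (Homo sapiens) for cytotoxicity, read by ATP content, with a stated time of 3 days; on this read-out higher numbers stand for lower toxicity in this test and lower numbers for higher toxicity in this test. Compound 1 `COc1ccc2c(c1)cc(Cn1c(=O)n(C3CC3)c3ccncc31)n2CCCCO` is measured first. In this assay compound 1 returns only the assay limit, > 50000 nM. Compound 2 `N#CCCCn1c(Cn2c(=O)n(-c3ccncc3F)c3ccncc32)cc2cc(Cl)ccc21` is the starting point of the step followed here. In this assay compound 2 likewise returns only a limit, > 50000 nM. Going by the values given here, compound 2 therefore stands where every number so far stands, namely at the limit of > 50000 nM in this assay, at which 2 of the 2 values shown sit; no measured pair differing in one place exists to size a step.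

Compound 3 `N#CCCCn1c(Cn2c(=O)n(-c3ccc(OC(F)(F)F)cc3)c3ccncc32)cc2cc(Cl)ccc21` carries the change (4-(trifluoromethoxy)phenyl in place of 3-fluoropyridin-4-yl on an aromatic nitrogen). With only limits to go on, the author expects no step beyond the usual scatter, the step of a number no higher from compound 2 to compound 3 (the limit leaves the size open) being estimated as flat. Compound 3 is accordingly expected to give 50000 nM in this assay, with a range from 20000 nM to 50000 nM, most likely again reported as a limit.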

Compound 3, half-maximal cytotoxic concentration: > 50000 nM
Compound 3: a limit, no number; the forecaster's own chance of this, stated with the estimate: 65%; the middle value lies on the limit itself.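

Going by these compounds alone, compound 2 and compound 3 both return only a limit in this assay, so no step between them can be read. The compounds shown leave open whether 4-(trifluoromethoxy)phenyl in place of 3-fluoropyridin-4-yl on an aromatic nitrogen changes the half-maximal cytotoxic concentration at all.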